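Thiophene for phenyl on the shared core: cytotoxicity outlook

The source may report more compounds than this note shows. Statements on the series, on what has been measured and on what is new or still open speak of the compounds shown alone.

The series is followed in an ADME assay on HEL cells (Homo sapiens) for cytotoxicity, with a stated time of 3 days; on this read-out higher numbers stand for lower toxicity in this test and lower numbers for higher toxicity in this test. Compound 1 `Cc1cc(-c2ccccc2)c2ncc(CSCCc3ccccc3)n2c1` gives 33 ug/mL in this assay. Within the data shown here, compound 2 `c1ccc(CCSCc2cnc3ccc(-c4ccccc4)cn23)cc1` gives 9.9 ug/mL in this assay, so compound 1 holds the higher of the two numbers, and the gap between them lies beyond the scatter; the two structures differ in more than one place, so only the pair of values can be stated. Compound 3 `Cc1cc(-c2ccc(O)cc2)cn2c(CSCCc3ccccc3)cnc12` returns only a limit in this assay, > 50 ug/mL. That limit is the ceiling of the measurement, as noted in the limit of > 50 ug/mL in this assay, at which 1 of the 3 values shown sits.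

Compound 4 `Cc1cc(-c2cccs2)c2ncc(CSCCc3ccccc3)n2c1` is not yet measured. It differs from compound 1 by thiophen-2-yl in place of phenyl on an aromatic carbon. Among the measured compounds shown here, no measured pair in the set isolates this change, so no direction can be read from the data. The expectation is therefore a step of no size beyond the scatter, with the result near the value of compound 1. Compound 4 is estimated at 30 ug/mL, with a range from 14 ug/mL to 50 ug/mL. The expected step of a 1.1-fold lower number from compound 1 to compound 4 (0.04 log units; within the scatter) is taken to stay within the scatter, with some chance that the read-out reaches the limit instead.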

Compound 4, half-maximal cytotoxic concentration: > 50 ug/mL
Compound 4 gave a limit, no number; the forecaster's own chance of this, stated with the estimate: 20%; middle value at least 1.6-fold (0.22 log units) from the limit.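

In this assay, among these compounds, thiophen-2-yl in place of phenyl on an aromatic carbon, ortho to a fused ring, gives the first change that can be read in one place: an at least 1.5-fold higher number from compound 1 to compound 4 (0.18 log units; that floor lies within the scatter). The value of compound 4, > 50 ug/mL, is a limit of the assay and not a number, so the step has only a floor, and with that floor inside the scatter, a true rise is not established, although the swap at this position shows no sign of a lower number. The limit now holds a second compound of the set: the limit of > 50 ug/mL in this assay, at which 2 of the 4 values shown sit.

Going by these compounds, how far compound 4 would sit past the limit remains open, as does whether the same swap would behave alike at another position on the shared core. Also open, on these data alone, is whether an amine or a carboxylic acid carried on the thiophen-2-yl ring, or a five-membered aromatic ring with an oxygen in place of the sulfur, would keep the read-out at the limit or bring it back to a number.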